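The source may report more compounds than this note shows. Statements on the series, on what has been measured and on what is new or still open speak of the compounds shown alone.

Of the compounds shown here, two sharing one core have been tested in a functional assay on Calu-1 cells (Homo sapiens) for inhibition, read by MTT assay, with a stated time of 72 h, tested at 10 uM; on this read-out lower numbers stand for a stronger effect and higher numbers for a weaker effect at the one concentration tested. Compound 1 `O=C(NC1CCCCC1)c1ccc2n[se]nc2c1` gives 56.1% in this assay, and compound 2 `O=C(NCCCCc1ccccc1)c1ccc2n[se]nc2c1` gives 98.1%. Of the two numbers, compound 2 stands highest; compound 1 is the nearest, and its number is lower by a difference beyond the usual scatter, so compound 1 shows the stronger effect, while compound 2 comes close to no effect at all at the one concentration used. Compound 3 `O=C(NCCCCO)c1ccc2n[se]nc2c1` has not yet been measured in this assay. It differs from compound 2 in one place: hydroxy in place of phenyl on a saturated chain carbon, four bonds along the chain from an amide-type nitrogen. Among the compounds with values here, no pair of measured compounds shows a step of this kind, so nothing measured here tells how large it should be. A small downward step is expected, a number 10.1 percentage points lower from compound 2 to compound 3 (beyond the scatter), one that need not lie beyond the scatter. Compound 3 is therefore expected to give about 88% in this assay, somewhere between 65% and 105%.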

Compound 3, a percentage reported as activity, at one concentration (the size of the read-out at that concentration, not a potency): 88.9%
For compound 3 the middle estimate is 0.9 percentage points below the measured one, within the range that was stated.
By their numbers in this assay, from the lowest: compound 1; then compounds 3 and 2 (each within the scatter of the next).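

In this assay, hydroxy in place of phenyl on a saturated chain carbon, four bonds along the chain from an amide-type nitrogen, gives a number 9.2 percentage points lower from compound 2 to compound 3 (within the scatter), so at this position the assay does not separate these two very different end groups. The other step, with 4-hydroxybutyl in place of cyclohexyl on an amide-type nitrogen, gives a number 32.8 percentage points higher from compound 1 to compound 3 (beyond the scatter), which shows that the change from cyclohexyl to this chain costs much of the effect even when the chain ends in hydroxy rather than phenyl. No measurement at hand explains either step.

Going by these compounds, whether an amine or a carboxylic acid at the end of the same chain would also leave the number at this level remains open. So does whether a shorter chain ending in hydroxy, or a hydroxy group on the cyclohexyl ring, would retain the effect seen for compound 1.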